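Stereochemical variant of the tertiary alcohol analogue

The source may hold more compounds than are shown below. What is called first, only, known or untested is meant among the compounds shown, and "the series" means these compounds.

Measured so far:
compound 1 `C=C/C=C\[C@H](C)[C@H](OC(N)=O)[C@@H](C)[C@H](O)[C@@H](C)/C=C(\C)[C@H]1[C@H](C)[C@@H](O)[C@@H](C)[C@@H]1/C=C/C[C@@H]1OC(=O)[C@H](C)[C@@H](O)[C@H]1C` — 2130 nM
compound 2 `C=C/C=C\[C@H](C)[C@H](OC(N)=O)[C@@H](C)[C@H](O)[C@@H](C)CC(=C)[C@H]1[C@H](C)[C@@H](O)[C@@H](C)[C@@H]1/C=C/C[C@@H]1OC(=O)[C@H](C)[C@@H](O)[C@H]1C` — 190 nM
compound 3 `C=C/C=C\[C@H](C)[C@H](OC(N)=O)[C@@H](C)[C@H](O)[C@@H](C)C[C@@](C)(O)[C@H]1[C@H](C)[C@@H](O)[C@@H](C)[C@@H]1/C=C/C[C@@H]1OC(=O)[C@H](C)[C@@H](O)[C@H]1C` — 2420 nM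

In a functional assay on P388 cells (Mus musculus) for cytotoxicity (on this read-out higher numbers stand for weaker inhibition and lower numbers for stronger inhibition), compound 3 gives 2420 nM, the highest number of the three. Compound 1 lies within the scatter of it, while compound 2 sits well below both, the one clearly stronger inhibitor in this set.

Compound 4 `C=C/C=C\[C@H](C)[C@H](OC(N)=O)[C@@H](C)[C@H](O)[C@H](C)C[C@](C)(O)[C@H]1[C@H](C)[C@@H](O)[C@@H](C)[C@@H]1/C=C/C[C@@H]1OC(=O)[C@H](C)[C@@H](O)[C@H]1C` is to be measured. Relative to compound 3: the two compounds have the same atoms and bonds and differ only in configuration as drawn: 2 of 17 stereo elements differ; a stereocentre at a saturated chain carbon is drawn S in compound 3 and R in compound 4; a stereocentre at a saturated chain carbon is drawn R in compound 3 and S in compound 4. Among the compounds with values here, no measured pair shows a configurational change alone, so the direction is open. For compound 4 the step is expected to be a 1.4-fold higher number from compound 3 to compound 4 (0.16 log units; within the scatter), with a weakening or no change beyond the scatter judged more likely than an improvement. Compound 4 is thus estimated at 3500 nM, between 1000 nM and 15000 nM.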

Compound 4, half-maximal inhibitory concentration: 7650 nM
Compound 4: middle estimate off by 2.2-fold (0.34 log units), on the low side; the range from low to high includes it.
By their numbers in this assay, from the lowest: compound 2; then compounds 1 and 3 (each within the scatter of the next); then compound 4.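

In this assay, within the data shown here, the series shows a 3.2-fold higher number from compound 3 to compound 4 (0.50 log units; beyond the scatter), the first step here that involves configuration alone. With no atom or bond changed, the drawn configuration at two saturated chain carbons is enough to move the number beyond the scatter: the fact that compounds 3 and 4 differ only in the configuration as drawn.

Both stereocentres change together, so the share of each in this step cannot be separated. Also open, going by these compounds, is whether an amine or a methyl ether in place of the tertiary alcohol would respond to the same configurational change.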